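A few compounds are considered here, and "the series" means these few. Any claim that something is new, unique, unknown or untested is made for them only; others in the source may bear on it.

Of the compounds shown here, two have so far been measured in an in vitro assay on cells for inhibition of Amine oxidase [flavin-containing] B (Homo sapiens), read by Amplex Red, with a stated time of 15 min; a higher number here means a weaker inhibitor, a lower number a stronger inhibitor. Compound 1 `COc1ccc(/C=C/C=C/C(=O)c2cc(Cl)ccc2O)cc1` gives 153 nM, the higher of the two numbers, and its nearest neighbour is compound 2 `O=C(/C=C/C=C/c1ccccc1)c1cc(Cl)ccc1O`, which gives 54.8 nM in this assay. Going by the values given here, the difference between them is the single change a 2.8-fold lower number from compound 1 to compound 2 (0.45 log units; beyond the scatter), a step beyond the usual scatter but still modest in size.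

Compound 3 `COc1ccc(/C=C/C=C/C(=O)c2cc(F)ccc2O)cc1` has not been measured. It differs from compound 1 by fluoro in place of chloro on an aromatic carbon. Among the compounds with values here, no measured step bears directly on this change: the only measured step concerns the methoxy group on the other aromatic ring and leaves the halogen untouched, so there is nothing measured to say whether swapping one halogen for another here moves the number in this assay, or in which direction. With that gap in the evidence, the expected step is a 1.2-fold higher number from compound 1 to compound 3 (0.07 log units; within the scatter), which is within the usual scatter. Compound 3 is therefore estimated at 180 nM, with an expected range from 70 nM to 500 nM.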

Compound 3, half-maximal inhibitory concentration: 726 nM
Beside the measured number, compound 3's estimate is 4.0-fold (0.61 log units) below it; the whole stated range lies below it.
By their numbers in this assay, from the lowest: compound 2; then compound 1; then compound 3.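

The position para to a hydroxy group is not a silent one: in this assay, fluoro in place of chloro gives a 4.7-fold higher number from compound 1 to compound 3 (0.68 log units; beyond the scatter), the first measured sign that the halogen on this ring matters. By simple counts the exchange is small, one heavy atom for one heavy atom, with no change in ring, hydrogen-bond donors, hydrogen-bond acceptors or net charge, so these counts do not separate the two compounds even though their numbers differ beyond the scatter. Nothing measured here explains why this exchange shifts the number.

With only chloro and fluoro compared at this position, and in a single pair, the compounds shown leave open whether the number follows any trend across substituents there, as bromo, methyl or an amine might help to show. They also leave open whether fluoro in place of chloro would have a similar effect on compound 2, which lacks the methoxy group, or whether the two changes combine in some other way.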